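The compounds below may be only part of what the source reports. "The series", "measured", "known", "first", "only" and "open" are said of these compounds alone.

Of the compounds shown here, three have so far been measured in an assay on isolated protein for binding affinity to Equilibrative nucleoside transporter 1 (Homo sapiens); a lower number here means a stronger inhibitor, a higher number a weaker inhibitor. Compound 1 `OC[C@H]1O[C@@H](n2cnc3c(SCC4CCCCC4)ncnc32)[C@H](O)[C@@H]1O` gives 1550 nM and stands at the lowest of the three numbers. Compound 2 `Nc1nc(SCc2cccc(Br)c2)c2ncn([C@@H]3O[C@H](CO)[C@@H](O)[C@H]3O)c2n1` gives 2880 nM in this assay, a number that lies within the scatter of that of compound 1, so the two cannot be told apart. Compound 3 `CCCCn1cnc2c(SC(C)C)nc(N)nc21` gives 120000 nM in this assay, a gap from compound 1 that lies well beyond the scatter.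

The step of interest leads from compound 1 to compound 4 `OC[C@H]1O[C@@H](n2cnc3c(CSc4cccc(Cl)c4)ncnc32)[C@H](O)[C@@H]1O`, which has not yet been measured. The change is a group of 9 heavy atoms (7 carbon, 1 sulfur, 1 chlorine; one six-membered aromatic ring of carbon only) in place of a group of 8 heavy atoms (7 carbon, 1 sulfur; one six-membered non-aromatic ring of carbon only), on an aromatic carbon. Within the data shown here, no step between two measured compounds matches this change, so its size cannot be read from the data. Compound 2, which also carries a halogen-bearing aromatic ring of carbon only joined through sulfur on a related core, lands within the scatter of compound 1, which hints that such a group is tolerated. Compound 4 is therefore expected to stay near compound 1, with a step of a 1.9-fold higher number from compound 1 to compound 4 (0.29 log units; within the scatter) that may fall within the scatter or run modestly toward a weaker inhibitor. Compound 4 is estimated at 3000 nM, within a range of 800 nM to 12000 nM.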

Compound 4, half-maximal inhibitory concentration: 282 nM
Estimate against measurement, compound 4: 11-fold (1.03 log units) above; the whole stated range lies above it.
By their numbers in this assay, from the lowest: compound 4; then compounds 1 and 2 (each within the scatter of the next); then compound 3.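

In this assay, among these compounds, the replacement gives a 5.5-fold lower number from compound 1 to compound 4 (0.74 log units; beyond the scatter) and this is the only reading so far of a change at this aromatic carbon of the shared core. It shows that the position does more than accept a new group: the (cyclohexylmethyl)sulfanyl group can give way to a group with a chlorine-bearing aromatic ring of carbon only, with a gain toward a stronger inhibitor that lies beyond the scatter, even though the heavy-atom counts of the two groups lie close together. The data hold no measurement that accounts for this gain.

The step changes several things at once, since the non-aromatic ring becomes an aromatic one, a chlorine enters, and the sulfur and carbon of the link swap order, so the compounds shown leave open which of these carries the gain. They also leave open whether the chlorine matters at all, which a plain phenyl ring on the same link, or one bearing a methoxy group or a fluorine instead of the chlorine, would help to settle.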